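Notes on the acyl change from compound 3 to compound 4

This account rests on a few compounds, and the source may have more. Where it says the series, first, only, none or still open, it means among the compounds named here.

Measured so far in a toxicity assay on J774.1 cells (Mus musculus) for cytotoxicity, read by MTT assay, with a stated time of 48 h; on this read-out higher numbers stand for lower toxicity in this test and lower numbers for higher toxicity in this test:
compound 1 `CC(=O)N(Cc1ccccc1C(=O)N[C@H](/C=C/S(=O)(=O)c1ccccc1)CCc1ccccc1)C(C)=O`: 36000 nM
compound 3 `CC(=O)NCc1ccccc1C(=O)N[C@H](/C=C/S(=O)(=O)c1ccccc1)CCc1ccccc1`: 48000 nM
compound 2 `O=C(NCc1ccccc1C(=O)N[C@H](/C=C(\F)S(=O)(=O)Oc1ccccc1)CCc1ccccc1)c1ccc2c(c1)OCCO2`: a limit, > 100000 nM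

Compound 3 holds the higher of the two numbers, though compound 1 at 36000 nM lies within the scatter of it, as the step of a 1.3-fold higher number from compound 1 to compound 3 (0.12 log units; within the scatter) shows. For compound 2 the assay reports only a limit, > 100000 nM, namely (the limit of > 100000 nM in this assay, at which 1 of the 3 values shown sits). Compound 4 `O=C(O)c1cccc(C(=O)NCc2ccccc2C(=O)N[C@H](/C=C/S(=O)(=O)c2ccccc2)CCc2ccccc2)c1` differs from compound 3 by 3-carboxyphenyl in place of methyl on a carbonyl carbon. Among the measured compounds shown here, no measured step covers a change on this carbonyl carbon; the one step measured, hydrogen in place of acetyl on an amide-type nitrogen, stayed within the scatter, so no step beyond the scatter is expected here. The step to compound 4 is expected to be a 1.3-fold higher number from compound 3 to compound 4 (0.10 log units; within the scatter). The estimate for compound 4 is 60000 nM, expected to fall between 25000 nM and 150000 nM.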

Compound 4, half-maximal cytotoxic concentration: > 100000 nM
Compound 4: only a limit was reported; the forecaster's own chance of this, stated with the estimate: 30%; middle value at least 1.6-fold (0.22 log units) away from the limit.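

Placing 3-carboxyphenyl on this carbonyl carbon gives an at least 2.0-fold higher number from compound 3 to compound 4 (0.31 log units; beyond the scatter) in this assay, a step beyond the scatter, whereas the earlier change on the amide-type nitrogen stayed within it. Against the diacetylamino compound, the change reads as an at least 2.7-fold higher number from compound 1 to compound 4 (0.44 log units; beyond the scatter), so both steps point to lower toxicity in this test. Compound 4 has only a limit in this assay, not a number: the limit of > 100000 nM in this assay, at which 2 of the 4 values shown sit.

From the compounds shown here alone, the full size of both steps stays open. Also open, going by these compounds, is whether the ring or its acid carries the step: a plain benzoyl group, or an amine on that ring, would separate the two.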